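The compounds below may be only part of what the source reports. "The series", "measured", "known", "first", "only" and "open" are said of these compounds alone.

Of the compounds shown here, three that share one core have so far been measured in an assay on cells for displacement of a labelled ligand from Neuronal acetylcholine receptor; alpha3/beta4 (Homo sapiens); a lower number here means a stronger inhibitor, a higher number a weaker inhibitor. Compound 1 `O=C(Nc1ccc(I)cc1)c1cncc(N2CC3CC(C2)N3)c1` gives 103 nM. Compound 2 `O=C(Nc1ccccc1F)c1cncc(N2CC3CC(C2)N3)c1` gives 102 nM. Compound 3 `COc1ccc(NC(=O)c2cncc(N3CC4CC(C3)N4)c2)cc1OC` gives 516 nM. Compound 2 has the lowest of the three numbers, though its nearest neighbour, compound 1, sits within the usual scatter of it, the step from compound 1 to compound 2 being a 1.0-fold lower number from compound 1 to compound 2 (0.00 log units; within the scatter). The gap to compound 3 is wider, and the two values show a markedly higher number for compound 3.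

Compound 4 `O=C(Nc1ccccc1)c1cncc(N2CC3CC(C2)N3)c1` has not yet been measured. It differs from compound 2 by hydrogen in place of fluoro on an aromatic carbon. Among the compounds with values here, the only measured step that bears on a change at this part of the molecule is the one from compound 1 to compound 2, where swapping one substituent on the six-membered aromatic ring for another gave a 1.0-fold lower number from compound 1 to compound 2 (0.00 log units; within the scatter), a step within the scatter. On that single precedent, removing the fluoro is expected to produce only a small change, a 1.3-fold higher number from compound 2 to compound 4 (0.11 log units; within the scatter), with no direction clearly favoured. Compound 4 is therefore expected to show about 130 nM in this assay, within a range from 60 nM to 280 nM.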

Compound 4, inhibition constant: 192 nM
Beside the measured number, compound 4's estimate is 1.5-fold (0.17 log units) below it; measured number inside the range.
By their numbers in this assay, from the lowest: compounds 2, 1 and 4 (each within the scatter of the next); then compound 3.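

Within the data shown here, compound 4 carries a plain phenyl with no substituent, so it gives the first reading of this ring without a halogen. In this assay, going from 2-fluorophenyl to phenyl gives a 1.9-fold higher number from compound 2 to compound 4 (0.27 log units; within the scatter) and hydrogen in place of the iodo gives a 1.9-fold higher number from compound 1 to compound 4 (0.27 log units; within the scatter) and so, with both steps within the scatter, these compounds cannot be told apart, and neither halogen is shown to be needed for binding at this level. Nothing measured here accounts for these readings.

From the compounds shown here alone, what remains open is whether a different kind of group on an aromatic carbon ortho to a large group, such as an amine, a nitrile or a carboxylic acid, would give a step beyond the scatter. The compounds shown also keep an aromatic ring on the amide nitrogen, so the effect of a longer chain in place of that ring is unknown.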